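Adding a chloro group to the weakest of three sulfonamides

This account rests on a few compounds, and the source may have more. Where it says the series, first, only, none or still open, it means among the compounds named here.

Of the compounds shown here, three share one core and have been tested in a functional assay on OVCAR-3 cells (Homo sapiens) for antiproliferative activity, read by MTT assay, with a stated time of 24 h; on this read-out higher numbers stand for weaker inhibition and lower numbers for stronger inhibition. Compound 1 `O=c1[nH]cc(S(=O)(=O)Nc2ccccc2-c2cn(-c3cccc(Cl)c3)nn2)c(=O)[nH]1` gives 2180 nM. Compound 2 `O=c1[nH]cc(S(=O)(=O)Nc2cccc(-c3cn(-c4cccc(Cl)c4)nn3)c2)c(=O)[nH]1` gives 3410 nM. Compound 3 `O=c1[nH]cc(S(=O)(=O)Nc2ccc(-c3cn(-c4ccccc4)nn3)cc2)c(=O)[nH]1` gives 18000 nM, the highest of the three numbers, so it is the weakest inhibitor here; the gap to compound 2 and the gap to compound 1 both lie beyond the usual scatter.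

Compound 4 `O=c1[nH]cc(S(=O)(=O)Nc2ccc(-c3cn(-c4ccc(Cl)cc4)nn3)cc2)c(=O)[nH]1` is not yet measured. It differs from compound 3 in one place: chloro in place of hydrogen on an aromatic carbon. Compound 1 and compound 2 also carry a chloro group, yet they differ from compound 3 in other places as well, so their numbers do not show what this single change alone does.

The expectation is a modest step toward stronger inhibition, a 2.0-fold lower number from compound 3 to compound 4 (0.30 log units; within the scatter), possibly no larger than the scatter. Compound 4 is therefore estimated at 9000 nM, with a range from 3000 nM to 25000 nM.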

Compound 4, half-maximal inhibitory concentration: 2160 nM
Beside the measured number, compound 4's estimate is 4.2-fold (0.62 log units) above it; measured number outside the range, below it.
By their numbers in this assay, from the lowest: compounds 4, 1 and 2 (each within the scatter of the next); then compound 3.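

In this assay, replacing phenyl with 4-chlorophenyl gives an 8.3-fold lower number from compound 3 to compound 4 (0.92 log units; beyond the scatter), so a single chloro group on this ring, para to a large group, can change the number substantially on its own. The earlier compounds shown here could not show this, as the chloro groups of compound 1 and compound 2 came with other differences from compound 3, whereas here nothing else changes. The data shown offer no measurement that explains this shift.

On these data alone, whether a fluoro group, a methyl group or an amine in the same place would move the number as far remains open. So does what removing the chloro group from compound 1 or compound 2 would do, since neither compound has a partner here that differs only in that one place.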